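The source may report more compounds than this note shows. Statements on the series, on what has been measured and on what is new or still open speak of the compounds shown alone.

In a physicochemical assay for lipophilicity (a higher number here means a more lipophilic compound, a lower number a more polar compound), compound 1 `C=C(c1cccc2ccccc12)C1CCC2(CC1)COC(Nc1ccccc1)OO2` gives 5.59, compound 2 `C=C(c1cccc2ccccc12)C1CCC2(CC1)COC(Nc1ccc(F)cc1)OO2` gives 5.75 and compound 3 `C=C(c1ccc2ccccc2c1)C1CCC2(CC1)COC(Nc1ccc(F)cc1)OO2` gives 5.75. Compound 3 therefore stands level with compound 2, and all three numbers lie within the scatter of one another.

The next compound is compound 4 `C=C(c1ccc2ccccc2c1)C1CCC2(CC1)COC(Nc1cccc(C(F)(F)F)c1)OO2`, with 3-(trifluoromethyl)phenyl in place of 4-fluorophenyl on an amine nitrogen.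

Two measured steps are available. Fluoro in place of hydrogen on an aromatic carbon gave a number 0.16 log units higher from compound 1 to compound 2 (within the scatter), and this is the only step that alters the same aromatic group. Naphthalen-2-yl in place of naphthalen-1-yl gave no change at the digits printed from compound 2 to compound 3 (within the scatter), but that swap lies at the other end of the molecule and says little about the amine nitrogen substituent. Within the data shown here, no measured compound carries trifluoromethyl, so the size of the new step cannot be read directly from the series.

Among the measured compounds shown here, the one relevant precedent is small, but more carbon and fluorine enter here than leave, so a larger upward move in this assay is expected, probably beyond the scatter. The expected step is a number 0.55 log units higher from compound 3 to compound 4 (beyond the scatter). For compound 4 the estimated value is 6.3, with an expected range from 5.9 to 6.7.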

Compound 4, partition coefficient: 6.51
Compound 4: the middle estimate sits 0.21 log units below what was measured; the range from low to high includes it.
By their numbers in this assay, from the lowest: compounds 1, 2 and 3 (each within the scatter of the next); then compound 4.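

Among these compounds, on the amine nitrogen, 3-(trifluoromethyl)phenyl in place of 4-fluorophenyl gives a number 0.76 log units higher from compound 3 to compound 4 (beyond the scatter) in this assay, the first step to pass the scatter. The earlier changes gave a number 0.16 log units higher from compound 1 to compound 2 (within the scatter) on the same aromatic group and, with naphthalen-2-yl in place of naphthalen-1-yl, no change at the digits printed from compound 2 to compound 3 (within the scatter), so only now does the group on the amine nitrogen stand out as a place where this read-out moves clearly, with 10 heavy atoms entering where 7 leave and one six-membered aromatic ring of carbon only on both sides. Nothing measured here accounts for the size of this step.

From the compounds shown here alone, whether the step belongs to trifluoromethyl as such or to where it sits on the ring stays open, as does whether a step of this size would also appear with naphthalen-1-yl at the other end of the molecule. A nitrile, a carboxylic acid or an amine on the same aromatic group would show how far this assay can be brought back down from this position.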